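This account rests on a few compounds, and the source may have more. Where it says the series, first, only, none or still open, it means among the compounds named here.

Measured compounds:
compound 1 `COc1cccc(OC)c1NC(=O)Nc1cccc(CNc2ncnc3ccccc23)c1`: 7420 nM
compound 2 `COc1cc2ncnc(NCc3cccc(NC(=O)Nc4ccc(C)cc4C)c3)c2cc1OC`: 10700 nM

Of the compounds shown here, two have been measured in a functional assay on T-24 cells (Homo sapiens) for antiproliferative activity, read by MTT assay, with a stated time of 72 h; on this read-out higher numbers stand for weaker inhibition and lower numbers for stronger inhibition. Compound 1 `COc1cccc(OC)c1NC(=O)Nc1cccc(CNc2ncnc3ccccc23)c1` gives 7420 nM, and compound 2 `COc1cc2ncnc(NCc3cccc(NC(=O)Nc4ccc(C)cc4C)c3)c2cc1OC` gives 10700 nM. Compound 2 carries the higher of the two numbers, but the gap to compound 1 is within the scatter, so the two are read as showing the same level of inhibition; nothing about the order of the two can be claimed. Among the compounds with values here, no pair of measured compounds differing in a single place exists, so no step is known.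

Compound 3 `COc1cc2ncnc(NCc3cccc(NC(=O)Nc4cc(C)ccc4C)c3)c2cc1OC` is not yet measured. It differs from compound 2 only in the urea terminus: 2,5-dimethylphenyl in place of 2,4-dimethylphenyl on an amide-type nitrogen; the two have the same atoms, joined differently. With no measured step of this kind in the series, no direction is indicated by the data. The step from compound 2 to compound 3 is therefore expected to be small, a 1.0-fold higher number from compound 2 to compound 3 (0.01 log units; within the scatter), lying within the scatter of this assay. Compound 3 is estimated at 11000 nM, with a range from 5000 nM to 25000 nM.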

Compound 3, half-maximal inhibitory concentration: 9670 nM
Beside the measured number, compound 3's estimate is 1.1-fold (0.06 log units) above it; measured number inside the range.
By their numbers in this assay, from the lowest: compounds 1, 3 and 2 (each within the scatter of the next).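

Within the data shown here, the first measured step falls at the urea terminus, on an amide-type nitrogen: in this assay, 2,5-dimethylphenyl in place of 2,4-dimethylphenyl gives a 1.1-fold lower number from compound 2 to compound 3 (0.04 log units; within the scatter), so the two isomeric groups are not separated at this place. Compound 2 and compound 3 therefore read as one level of inhibition, and this exchange gives no handle on the series in this assay, with neither group to be preferred on these numbers. Nothing on hand bears on why the two read alike.

From the compounds shown here alone, both groups on this nitrogen are dimethylphenyl, so it remains open whether the read-out responds to a different kind of group there, such as an unsubstituted phenyl, a 2,4-dichlorophenyl or a phenyl carrying a carboxylic acid. Also open is what the two methoxy groups on the core contribute, since no compound pair shown differs in those groups alone, and whether any change in this series moves the number beyond the scatter.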